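Removing a Methyl from the Shared Core

The source may report more compounds than this note shows. Statements on the series, on what has been measured and on what is new or still open speak of the compounds shown alone.

Compound 1 `COC1=C(CC(C)(C)CNC(=O)c2ccccc2OC)C(=O)c2ccccc2C1=O` and compound 2 `COC1=C(CC(C)(C)CNC(=O)c2ccc3ccccc3c2OC)C(=O)c2ccccc2C1=O` are close relatives; the difference between the two cores is not broken down here. In a functional assay on KB cells (Homo sapiens) for cytotoxicity, read by resazurin assay, with a stated time of 3 days (a higher number here means a weaker inhibitor, a lower number a stronger inhibitor), compound 1 gives 33200 nM, and compound 2 gives 64100 nM. Compound 3 `COc1ccccc1C(=O)NCC(C)(C)CC1=C(O)C(=O)c2ccccc2C1=O` differs from compound 1 by hydrogen in place of methyl on an oxygen on an unsaturated carbon, and in this assay compound 3 gives 26300 nM, a step of a 1.3-fold lower number from compound 1 to compound 3 (0.10 log units; within the scatter). Compound 4 `COc1c(C(=O)NCC(C)(C)CC2=C(O)C(=O)c3ccccc3C2=O)ccc2ccccc12` differs from compound 2 by the same change, (hydrogen in place of methyl on an oxygen on an unsaturated carbon), and the surroundings of the place are described in the same words. Because the earlier step of a 1.3-fold lower number from compound 1 to compound 3 (0.10 log units; within the scatter) stayed within the scatter, compound 4 is expected to move by only a 1.2-fold lower number from compound 2 to compound 4 (0.09 log units; within the scatter). In this assay compound 4 is therefore estimated at 52000 nM, expected to fall between 22000 nM and 120000 nM.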

Compound 4, half-maximal inhibitory concentration: 66900 nM
The estimate for compound 4 lay 1.3-fold (0.11 log units) below the measured number, within the range that was stated.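

In this assay the methoxy to hydroxy change again makes little difference, with a 1.0-fold higher number from compound 2 to compound 4 (0.02 log units; within the scatter). Set side by side, the two steps agree, so in this small set the change carries from one core to the other as a step too small to read: the same change on two cores in this assay, a 1.3-fold lower number (0.10 log units; within the scatter) from compound 1 to compound 3 and a 1.0-fold higher number (0.02 log units; within the scatter) from compound 2 to compound 4, 1.3-fold (0.12 log units) apart, within the scatter of two such steps. This holds only for these two cores in this one assay, and it does not show that the change would stay as quiet on any other core, nor why it does so here.

The compounds shown leave open what a different group at the same place would do. An ethyl or longer chain on that oxygen is one such case, and an amine in place of the methoxy is another.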